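Changing the Carboxyphenyl End in a Thallium-Flux Assay

The compounds below may be only part of what the source reports. "The series", "measured", "known", "first", "only" and "open" are said of these compounds alone.

Measured compounds:
compound 1 `Cc1c(OCCCCOc2ccc(F)c(C(=O)O)c2)ccc(C(=O)CC2CCCC2)c1O` gives 81%
compound 2 `Cc1c(OCCCCOc2ccccc2C(=O)O)ccc(C(=O)CC2CCCC2)c1O` gives 98.8%
compound 3 `Cc1c(OCCCCOCOc2ccc(C(=O)O)cc2)ccc(C(=O)CC2CCCC2)c1O` gives 95.4%

All three were tested in an assay on HEK293 cells for positive allosteric modulation of metabotropic glutamate receptor 2 (Rattus norvegicus), read by thallium flux, with a stated time of 2.5 min; on this read-out lower numbers stand for smaller maximal responses and higher numbers for larger maximal responses. Compound 3 stands second highest of the three numbers; its nearest neighbour is compound 2, and the step of a number 3.4 percentage points lower from compound 2 to compound 3 (within the scatter) lies within the scatter, so the two cannot be told apart. Compound 1 sits clearly lower, as the steps of a number 17.8 percentage points higher from compound 1 to compound 2 (beyond the scatter) and a number 14.4 percentage points higher from compound 1 to compound 3 (beyond the scatter) show.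

Compound 4 `Cc1cc(OCCCCOc2ccc(C(=O)CC3CCCC3)c(O)c2C)ccc1C(=O)O` has not yet been measured. It differs from compound 3 as follows: 4-carboxy-3-methylphenyl in place of (4-carboxyphenoxy)methyl on an oxygen on a saturated carbon

Among the compounds with values here, the steps that bear on this change are those among compounds 2 and 3, where two different carboxyphenyl-containing ends attached to the same oxygen gave numbers within the scatter of each other. Only the fluorinated end of compound 1 fell clearly lower. The expected step is therefore a number 2.4 percentage points lower from compound 3 to compound 4 (within the scatter), that is, none beyond the scatter. Compound 4 is estimated at 93%, with a range from 78% to 106%.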

Compound 4, largest response reached (reported as percent of maximum), in percent of the reference or control that the assay uses: 83.6%
For compound 4 the middle estimate is 9.4 percentage points above the measured one; low and high end bracket the measured number.
By their numbers in this assay, from the lowest: compounds 1 and 4 (each within the scatter of the next); then compounds 3 and 2 (each within the scatter of the next).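

The change gives a number 11.8 percentage points lower from compound 3 to compound 4 (beyond the scatter) and a number 15.2 percentage points lower from compound 2 to compound 4 (beyond the scatter) so the end on this oxygen matters more than the close numbers of compound 2 and compound 3 alone suggested. The comparison with the fluorinated end gives a number 2.6 percentage points higher from compound 1 to compound 4 (within the scatter) so a lower maximal response is not confined to the end carrying fluorine. Nothing available gives a reason for these differences.

On these data alone, it remains open whether the methyl of 4-carboxy-3-methylphenyl accounts for the lower number; a plain 4-carboxyphenyl end on the same oxygen would help to settle that. Every end shown carries a carboxylic acid, so how an end with a tetrazole in its place would behave also remains unknown.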